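A few compounds are considered here, and "the series" means these few. Any claim that something is new, unique, unknown or untested is made for them only; others in the source may bear on it.

Of the compounds shown here, three built on one shared core have been measured in a functional assay on cells (Leukemia cell, Homo sapiens) for cytotoxicity, read by sulforhodamine B assay, with a stated time of 48 h; a lower number here means a stronger inhibitor of growth, a higher number a weaker inhibitor of growth. Compound 1 `O=C1N=C(N2N=C(c3ccccc3)CC2c2ccccc2O)S/C1=C1/C(=O)Nc2ccccc21` gives 3190 nM. Compound 2 `COc1ccc(C2CC(c3ccccc3)=NN2C2=NC(=O)/C(=C3\C(=O)Nc4ccccc43)S2)cc1` gives 1640 nM, and the step of a 1.9-fold lower number from compound 1 to compound 2 (0.29 log units; within the scatter) stays inside the scatter. Compound 3 `COc1ccc(C2=NN(C3=NC(=O)/C(=C4\C(=O)Nc5ccccc54)S3)C(c3ccc(OC)cc3)C2)cc1` gives 100000 nM, the highest of the three numbers, reached through the step of a 61-fold higher number from compound 2 to compound 3 (1.79 log units; beyond the scatter), which was large. The next compound, compound 4 `COc1ccc(C2=NN(C3=NC(=O)/C(=C4\C(=O)Nc5ccc(Cl)cc54)S3)C(c3ccc(OC)cc3)C2)cc1`, differs from compound 3 by chloro in place of hydrogen on an aromatic carbon. For the measured compounds named here, neither measured step touches this part of the core: both earlier steps alter groups on the other two rings, so no measured step bears on this change directly. With no evidence either way, the expected step of a 1.1-fold lower number from compound 3 to compound 4 (0.05 log units; within the scatter) is none beyond the scatter. The estimate for compound 4 in this assay is therefore 90000 nM, with a range from 20000 nM to 300000 nM. Because compound 3 gives 100000 nM, a number at the top of what was seen, the expected number for compound 4 is placed close to it.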

Compound 4, concentration for 50% growth inhibition: 280 nM
Compound 4: middle estimate off by 320-fold (2.51 log units), on the high side, outside the stated range (below it).
By their numbers in this assay, from the lowest: compound 4; then compounds 2 and 1 (each within the scatter of the next); then compound 3.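

In this assay, this aromatic carbon of the fused two-ring system proves highly sensitive: chloro in place of hydrogen, a change of one heavy atom, brings a 360-fold lower number from compound 3 to compound 4 (2.55 log units; beyond the scatter) as a large step beyond the scatter. Compound 4 keeps both methoxy groups of compound 3, so those groups alone do not fix the number at the high end. Nothing measured here explains why this single substitution has so large an effect.

The compounds shown leave open whether chloro itself matters or whether another group at this carbon, such as fluoro, methyl, an amine or a carboxylic acid, would give a similar step. They also leave open whether chloro at this carbon would have as large an effect with the groups carried by compound 1 or compound 2.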